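Moving the Ring Oxygen: From Compound 2 to Compound 3

The source may hold more compounds than are shown below. What is called first, only, known or untested is meant among the compounds shown, and "the series" means these compounds.

Compound 1 `NC(=O)[C@@H](CCC(F)(F)F)N(CC1COC1)S(=O)(=O)c1ccc(Cl)cc1` and compound 2 `NC(=O)[C@@H](CCC(F)(F)F)N(C[C@@H]1CCCCO1)S(=O)(=O)c1ccc(Cl)cc1` share one core and differ only in the saturated ring attached to the chain carbon at the sulfonamide nitrogen. In an ADME assay on MDCKII-LE cells (Canis lupus familiaris) for permeability, read by transwell migration, in the apical to basolateral direction (a higher number here means that the compound crosses the layer faster, a lower number that the compound crosses the layer more slowly), compound 1 gives 25.4 10^-6 cm/s, and in this assay compound 2 gives 15.4 10^-6 cm/s. The step of a 1.6-fold lower number from compound 1 to compound 2 (0.22 log units; within the scatter) is the only one measured, and it lies within the scatter, so compound 2 and compound 1 sit together on the numbers shown rather than apart. Compound 3 `NC(=O)[C@@H](CCC(F)(F)F)N(CC1CCOCC1)S(=O)(=O)c1ccc(Cl)cc1` is built from compound 2 by the change (oxan-4-yl in place of oxan-2-yl on a saturated chain carbon bound to a sulfonamide nitrogen). Within the data shown here, the one measured step that bears on this, from a ring swap at the same position, was small, so the expected step of a 1.1-fold higher number from compound 2 to compound 3 (0.04 log units; within the scatter) is none beyond the scatter. In this assay compound 3 is therefore estimated at 17 10^-6 cm/s, with a range from 9 10^-6 cm/s to 32 10^-6 cm/s.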

Compound 3, apparent permeability: 26.3 10^-6 cm/s
Compound 3: middle estimate off by 1.5-fold (0.19 log units), on the low side, within the range that was stated.
By their numbers in this assay, from the lowest: compounds 2, 1 and 3 (each within the scatter of the next).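

Swapping oxan-2-yl for oxan-4-yl on a saturated chain carbon bound to a sulfonamide nitrogen moves the ring oxygen without changing the atoms, and in this assay this gives a small step (a 1.7-fold higher number from compound 2 to compound 3 (0.23 log units; within the scatter)). Set against the oxetan-3-yl group, oxan-4-yl gives an equally small step (a 1.0-fold higher number from compound 1 to compound 3 (0.02 log units; within the scatter)), so all three rings now stand together at this position, and neither the place of the ring oxygen nor the ring size separates them on the numbers shown. Nothing at hand explains these numbers.

Open, from the compounds shown here alone, is whether a ring holding an amine, such as piperidin-4-yl, or a carboxylic acid at this position would stay with these three compounds. Also open, going by these compounds, is whether the opposite stereocentre of the oxan-2-yl group would read the same.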